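Hydroxamate tether variation on the thiazole carboxamide series

This account rests on a few compounds, and the source may have more. Where it says the series, first, only, none or still open, it means among the compounds named here.

Measured so far:
compound 1 `CC(C)CCN(CCCCCC(=O)NO)c1ncc(C(=O)NCCCn2ccnc2)s1` — 20 nM
compound 2 `O=C(/C=C/c1ccc(CN(Cc2ccc(F)cc2)c2ncc(C(=O)NCCCn3ccnc3)s2)cc1)NO` — 14 nM

In an assay on isolated protein for inhibition of Nicotinamide phosphoribosyltransferase (Homo sapiens), read by fluorescence, with stated times of 5 min and 15 min (a lower number here means a stronger inhibitor, a higher number a weaker inhibitor), compound 2 gives 14 nM, the lowest of the two numbers; compound 1 gives 20 nM, and the gap between the two lies within the scatter. Compound 3 `O=C(CCCCCN(Cc1ccc(F)cc1)c1ncc(C(=O)NCCCn2ccnc2)s1)NO` is unmeasured. It differs from compound 2 by 4-(hydroxycarbamoyl)butyl in place of 4-(2-(hydroxycarbamoyl)ethenyl)phenyl on a saturated chain carbon bound to a nitrogen on an aromatic ring. Within the data shown here, no step between measured compounds addresses this change directly, but compound 1 already carries a saturated hydroxamate tether and gives 20 nM, so no step beyond the scatter is expected from compound 2 to compound 3 in this assay. Compound 3 is expected at 20 nM, range 7 nM to 60 nM, a step of a 1.4-fold higher number from compound 2 to compound 3 (0.15 log units; within the scatter).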

Compound 3, half-maximal inhibitory concentration: 7 nM
Estimate against measurement, compound 3: 2.9-fold (0.46 log units) above, within the range that was stated.
By their numbers in this assay, from the lowest: compounds 3, 2 and 1 (each within the scatter of the next, the first and the last beyond it).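

In this assay, 4-(hydroxycarbamoyl)butyl in place of 4-(2-(hydroxycarbamoyl)ethenyl)phenyl gives a 2.0-fold lower number from compound 2 to compound 3 (0.30 log units; within the scatter), so at this place the phenyl ring and ethenyl linker of the tether are not needed to hold a value of this order. Among these compounds, with the saturated tether kept, 4-fluorophenyl in place of isobutyl gives a 2.9-fold lower number from compound 1 to compound 3 (0.46 log units; beyond the scatter), the only step so far beyond the scatter. No measurement at hand gives a cause for either step. Open, going by these compounds, are how a longer chain than 4-(hydroxycarbamoyl)butyl reads in this assay, and whether a carboxylic acid can replace the hydroxycarbamoyl group.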